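A Chloro for Methoxy Swap on a Benzyl Triazole

The source may report more compounds than this note shows. Statements on the series, on what has been measured and on what is new or still open speak of the compounds shown alone.

In an assay on isolated protein for inhibition of biotin--protein ligase (Homo sapiens), read by scintillation counting, with a stated time of 10 min (a lower number here means a stronger inhibitor, a higher number a weaker inhibitor), compound 2 `COc1cccc(Cn2cc(CCCCC[C@@H]3SC[C@@H]4NC(=O)N[C@@H]43)nn2)c1` gives only a limit, > 16000 nM. Compound 1 `O=C1N[C@H]2[C@H](CS[C@H]2CCCCCc2cn(Cc3cccc(O)c3)nn2)N1` likewise gives only a limit in this assay, > 16000 nM. Compound 3 `Nc1ccccc1Cn1cc(CCCCC[C@@H]2SC[C@@H]3NC(=O)N[C@@H]32)nn1` also gives only a limit there, > 16000 nM. All three values sit at the limit of > 16000 nM in this assay, at which 3 of the 3 values shown sit, so the steps a step that the two limits leave unreadable from compound 1 to compound 2, a step that the two limits leave unreadable from compound 1 to compound 3 and a step that the two limits leave unreadable from compound 2 to compound 3 cannot be read in size or direction; they show only that none of the three substituents on the benzyl ring brought a measurable inhibition constant.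

Compound 4 `O=C1N[C@H]2[C@H](CS[C@H]2CCCCCc2cn(Cc3cccc(Cl)c3)nn2)N1` differs from compound 2 by chloro in place of methoxy on an aromatic carbon. Going by the values given here, no measured step touches a chloro group, and the steps that do exist are all unreadable. The expectation for compound 4 therefore rests on compound 2 alone, whose limit of > 16000 nM gives no number to move from. The step from compound 2 to compound 4 is expected to be a step that the limit leaves unreadable from compound 2 to compound 4, which is to say no resolvable change. Compound 4 is thus estimated at 20000 nM, within a range from 8000 nM to 60000 nM, most probably reported again only as a limit.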

Compound 4, inhibition constant: > 16000 nM
Compound 4 gave a limit, no number; the forecaster's own chance of this, stated with the estimate: 80%; the middle value does not contradict the limit.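

Going by these compounds alone, compound 4 gives only a limit in this assay and so do compound 1, compound 2 and compound 3, so no new step to compound 4 can be read in size or direction: the limit of > 16000 nM in this assay, at which 4 of the 4 values shown sit.

The compounds shown leave open what inhibition constant any of the four actually has, and whether chloro, methoxy, hydroxy or the 2-aminophenyl group differ at all.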